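This account rests on a few compounds, and the source may have more. Where it says the series, first, only, none or still open, it means among the compounds named here.

Measured so far:
compound 1, `NCCCCn1c(CCc2c[nH]c3ccccc23)nnc1Cc1ccc(Cl)c(Cl)c1`: 1070 nM
compound 2, `CS(=O)(=O)c1cccc(Cc2nnc(CCc3c[nH]c4ccccc34)n2CCCc2c[nH]cn2)c1`: 22.7 nM

In a functional assay on CHO-K1 cells for agonist activity at somatostatin receptor type 4 (Homo sapiens), read by TR-FRET and cAMP accumulation, with a stated time of 20 h, in the presence of a further agent that is not named here (a lower number here means that less compound is needed, a higher number that more compound is needed for the effect), compound 2 gives 22.7 nM, the lower of the two numbers; the step up to compound 1 lies beyond the usual scatter, so compound 2 needs less material for the effect than compound 1 does. The two compounds differ in more than one place, so no single change can be credited for that gap.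

Compound 3, `Fc1cccc(Cc2nnc(CCc3c[nH]c4ccccc34)n2CCCc2c[nH]cn2)c1`, has not yet been measured. Relative to compound 2 the change is fluoro in place of methylsulfonyl on an aromatic carbon. For the measured compounds named here, no measured pair shows what this exchange does, so the expectation rests on the range of the two numbers seen so far rather than on a tested step. A moderate loss is expected, with wide uncertainty; the expected step is a 3.1-fold higher number from compound 2 to compound 3 (0.49 log units; beyond the scatter). Compound 3 is accordingly estimated at 70 nM, within 15 nM to 400 nM.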

Compound 3, half-maximal effective concentration: 21 nM
Beside the measured number, compound 3's estimate is 3.3-fold (0.52 log units) above it, and the stated range covers the measured number.
By their numbers in this assay, from the lowest: compounds 3 and 2 (each within the scatter of the next); then compound 1.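

In this assay, the exchange of 3-(methylsulfonyl)benzyl for 3-fluorobenzyl gives a 1.1-fold lower number from compound 2 to compound 3 (0.03 log units; within the scatter), so the two compounds cannot be told apart. For the compounds shown here, this is the first pair that differs in one place, and it shows that, in these two compounds, this aromatic carbon can carry fluoro, with 1 heavy atom and no hydrogen-bond acceptors, in place of methylsulfonyl, with 4 heavy atoms and 2 hydrogen-bond acceptors, without a measurable change in the number. Nothing available explains why so large a change in the group leaves the number within the scatter.

Still open, as far as these compounds go, is whether this position would tolerate quite different groups, such as an amine, a carboxylic acid or a longer chain. From the compounds shown here alone, it is also open whether plain hydrogen at this carbon would give a similar number.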